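Replacing 4-ethylphenyl with cyclopentyl on the amide carbonyl

The source may hold more compounds than are shown below. What is called first, only, known or untested is meant among the compounds shown, and "the series" means these compounds.

Measured compounds:
compound 1 `CCCC(=O)N1CCC(NS(=O)(=O)c2ccc(NC(=O)c3ccccc3)c3ccccc23)CC1` — 12.5 nM
compound 2 `CCCC(=O)N1CCC(NS(=O)(=O)c2ccc(NC(=O)c3ccc(CC)cc3)c3ccccc23)CC1` — 10.8 nM

Compound 2 was tested in an in vitro functional assay on CHO/Galpha16 cells for antagonist activity at C-C chemokine receptor type 8 (Homo sapiens), read by FLIPR; on this read-out higher numbers stand for weaker inhibition and lower numbers for stronger inhibition. For the measured compounds named here, compound 2 stands at the lowest of the two numbers so far, but its only neighbour, compound 1, lies within the scatter of it: a 1.2-fold lower number from compound 1 to compound 2 (0.06 log units; within the scatter). The two compounds therefore cannot be told apart on this read-out.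

Compound 3 `CCCC(=O)N1CCC(NS(=O)(=O)c2ccc(NC(=O)C3CCCC3)c3ccccc23)CC1` is not yet measured. It shares the core of compound 2 and differs from it in one place: cyclopentyl in place of 4-ethylphenyl on a carbonyl carbon.

Going by the values given here, only one measured step exists, the one from compound 1 to compound 2, and it concerns an ethyl on an aromatic carbon, not the exchange of the ring itself. Among the compounds with values here, no step in the data tells what happens when the six-membered aromatic ring is traded for a five-membered non-aromatic ring. The expectation for compound 3 therefore rests on the two values alone and carries a wide range; a modest loss is expected, a 2.8-fold higher number from compound 2 to compound 3 (0.44 log units; beyond the scatter), with the possibility of no change beyond the scatter. Compound 3 is estimated at 30 nM, within 8 nM to 150 nM.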

Compound 3, half-maximal inhibitory concentration: 365 nM
Compound 3: the middle estimate sits 12-fold (1.09 log units) below what was measured, outside the stated range (above it).
By their numbers in this assay, from the lowest: compounds 2 and 1 (each within the scatter of the next); then compound 3.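

In this assay, the exchange of the ring on the carbonyl carbon has a large effect: cyclopentyl in place of 4-ethylphenyl gives a 34-fold higher number from compound 2 to compound 3 (1.53 log units; beyond the scatter) on this read-out, and cyclopentyl in place of phenyl gives a 29-fold higher number from compound 1 to compound 3 (1.47 log units; beyond the scatter) for the same exchange from the unsubstituted compound. Ethyl on the aromatic carbon had made no difference beyond the scatter, with a 1.2-fold lower number from compound 1 to compound 2 (0.06 log units; within the scatter), so this position, silent in the earlier step, now proves sensitive to the identity of the ring itself, whichever of the two aromatic acyl groups is the starting point. Nothing available accounts for the size of this rise.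

The compounds shown leave open whether the rise goes with the loss of the aromatic ring or with the change from a six-membered to a five-membered ring, a question that cyclohexyl on the same carbonyl carbon would separate. On these data alone, it also remains open whether the aromatic ring accepts groups unlike ethyl, such as an amine, a carboxylic acid or a longer chain, as readily as it accepts ethyl.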